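Carbamate selenocyanates: chain extension from compound 2

A few compounds are considered here, and "the series" means these few. Any claim that something is new, unique, unknown or untested is made for them only; others in the source may bear on it.

Three compounds carry numbers in a functional assay on HT-29 cells (Homo sapiens) for cytotoxicity, read by MTT assay, with a stated time of 72 h; a lower number here means a stronger inhibitor of growth, a higher number a weaker inhibitor of growth. Compound 1 `O=C(Nc1ccc([Se][Se]c2ccc(NC(=O)OCc3ccccc3)cc2)cc1)OCc1ccccc1` gives 1800 nM. Compound 2 `CCCCOC(=O)Nc1ccc([Se]C#N)cc1` gives 8100 nM, the highest of the three numbers. Compound 3 `Cc1ccc(OC(=O)Nc2ccc([Se][Se]c3ccc(NC(=O)Oc4ccc(C)cc4)cc3)cc2)cc1` gives 7900 nM; compound 2 and compound 3 sit within the scatter of each other, while the number of compound 1 lies beyond the scatter below that of compound 2. Compound 4 `CCCCCCOC(=O)Nc1ccc([Se]C#N)cc1` has not been measured in this assay. It differs from compound 2 by ethyl in place of hydrogen on a saturated chain carbon, four bonds along the chain from an oxygen next to a carbonyl group. Going by the values given here, no pair of measured compounds differs by such a change; a measured step is missing. The change is expected to move the number little, if at all, beyond the scatter, and the expected step is a 1.4-fold lower number from compound 2 to compound 4 (0.13 log units; within the scatter). Compound 4 is estimated at 6000 nM, with a range from 2000 nM to 20000 nM.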

Compound 4, concentration for 50% growth inhibition: 10700 nM
The estimate for compound 4 lay 1.8-fold (0.25 log units) below the measured number; low and high end bracket the measured number.
By their numbers in this assay, from the lowest: compound 1; then compounds 3, 2 and 4 (each within the scatter of the next).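

In this assay ethyl in place of hydrogen on this saturated chain carbon gives a 1.3-fold higher number from compound 2 to compound 4 (0.12 log units; within the scatter) and so leaves the number of compound 2 within the scatter. Going by these compounds alone, this is the first measured step at this position, and it shows that the chain of compound 2 takes this extension without a change beyond the scatter. No measurement at hand accounts for this result. From the compounds shown here alone, whether a longer chain, or an amine or a carboxylic acid in place of the ethyl, would move the number stays open.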